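The source may report more compounds than this note shows. Statements on the series, on what has been measured and on what is new or still open speak of the compounds shown alone.

The measured compounds:

Compound 1, `O=c1cc(CSC(=S)N2CCCCC2)oc2cc(Cl)ccc12`: in a functional assay on LM7 cells (Homo sapiens) for antiproliferative activity, read by MTT assay, with a stated time of 72 h (a higher number here means a weaker inhibitor, a lower number a stronger inhibitor), compound 1 gives 13800 nM.
Compound 2, `O=c1cc(CSC(=S)N2CCCC2)oc2cc(Cl)ccc12`: in this assay compound 2 gives > 25000 nM, which is a limit of the assay and not a number.
Compound 3, `O=c1c(CSC(=S)N2CCCCC2)coc2cc(Cl)ccc12`: in this assay compound 3 gives 850 nM.

Compound 4, `O=c1c(CSC(=S)N2CCCC2)coc2cc(Cl)ccc12`, has not yet been measured. Compound 1 and compound 3 are built from the same atoms joined differently; the difference between the two cores is not broken down here. What the two values show is that compound 3 gives the lower number of the two, and the gap is beyond the usual scatter.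

Within the core of compound 1, one change has been measured: pyrrolidin-1-yl in place of piperidin-1-yl on a thiocarbonyl carbon. It gave an at least 1.8-fold higher number from compound 1 to compound 2 (0.25 log units; that floor lies within the scatter). The size of that step is only a floor, since compound 2 sits at the limit of > 25000 nM in this assay, at which 1 of the 3 values shown sits, so the true step may be larger.

Compound 4 carries the same change on the core of compound 3: pyrrolidin-1-yl in place of piperidin-1-yl on a thiocarbonyl carbon. The expectation is that this change again raises the number, so compound 4 is estimated to give 2500 nM, between 900 nM and 9000 nM. That amounts to an expected step of a 2.9-fold higher number from compound 3 to compound 4 (0.47 log units; beyond the scatter), resting on the step from compound 1 to compound 2 and on the lower starting number of compound 3, which makes a measurable result rather than a limit more likely.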

Compound 4, half-maximal inhibitory concentration: 2600 nM
Compound 4: the middle estimate sits 1.0-fold (0.02 log units) below what was measured, within the range that was stated.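

In this assay, pyrrolidin-1-yl in place of piperidin-1-yl on a thiocarbonyl carbon gives a 3.1-fold higher number from compound 3 to compound 4 (0.49 log units; beyond the scatter), so on the core of compound 3 the change leaves a clearly weaker inhibitor. Compound 2 gives > 25000 nM, which is a limit of the assay and not a number, so the matching step on the core of compound 1 is known only as a floor. Nothing here goes against the change acting in the same direction on both cores, but two cores are too few to make a rule, and the size of the step cannot be said to carry over from one core to the other: the same change on two cores in this assay, an at least 1.8-fold higher number (0.25 log units; that floor lies within the scatter) from compound 1 to compound 2 and a 3.1-fold higher number (0.49 log units; beyond the scatter) from compound 3 to compound 4; the limit leaves it open whether they differ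

The compounds shown place only these two rings on the thiocarbonyl carbon, so they leave open how a morpholine ring, an azepane ring or an open-chain diethylamino group would behave on either core. They also leave open whether the same step would appear if the chlorine on the shared ring system gave way to a fluorine or a methoxy group, since every compound here carries that chlorine.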